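A New Group on the Carbonyl of Compound 3

The compounds below may be only part of what the source reports. "The series", "measured", "known", "first", "only" and "open" are said of these compounds alone.

compound 1 `CC(C)[C@H](NC(=O)c1ccccc1Br)C(=O)N1CCC[C@H]1C(=O)N[C@@H](CCCNC(=N)N)C(=O)CF` gives 4240 nM
compound 2 `CC(C)[C@H](NC(=O)c1ccc(Cl)cc1)C(=O)N1CCC[C@H]1C(=O)N[C@@H](CCCNC(=N)N)C(=O)CF` gives 1240 nM
compound 3 `COc1ccc(C(=O)N[C@H](C(=O)N2CCC[C@H]2C(=O)N[C@@H](CCCNC(=N)N)C(=O)CF)C(C)C)cc1` gives 1670 nM

These numbers come from a functional assay on OCI-Ly3 cells (Homo sapiens) for inhibition, read by CellTiter-Glo, with stated times of 48 h and 96 h; on this read-out higher numbers stand for weaker inhibition of growth and lower numbers for stronger inhibition of growth. Compound 3 stands at 1670 nM, and the gap to its nearest neighbour is a 1.3-fold higher number from compound 2 to compound 3 (0.13 log units; within the scatter). Its furthest neighbour is separated by a 2.5-fold lower number from compound 1 to compound 3 (0.40 log units; beyond the scatter).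

Compound 4 `CC(C)[C@H](NC(=O)Nc1ccc(Cl)cc1)C(=O)N1CCC[C@H]1C(=O)N[C@@H](CCCNC(=N)N)C(=O)CF` differs from compound 3 in one place: (4-chlorophenyl)amino in place of 4-methoxyphenyl on a carbonyl carbon. In words, (4-chlorophenyl)amino stands in place of 4-methoxyphenyl on a carbonyl carbon.

Two kinds of measured step bear on this. Replacing methoxy with chloro on an aromatic carbon gave a 1.3-fold higher number from compound 2 to compound 3 (0.13 log units; within the scatter), a step that stays within the scatter. Changing the group on the carbonyl carbon gave modest steps, a 3.4-fold lower number from compound 1 to compound 2 (0.53 log units; beyond the scatter) and a 2.5-fold lower number from compound 1 to compound 3 (0.40 log units; beyond the scatter), but both start from 2-bromophenyl. Among the compounds with values here, no measured compound carries the amino link, so the range must stay wide.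

The expected change is small, with no step beyond the scatter: a 1.2-fold lower number from compound 3 to compound 4 (0.08 log units; within the scatter). Compound 4 is estimated at 1400 nM, with an expected range from 500 nM to 4000 nM.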

Compound 4, concentration for 50% growth inhibition: 780 nM
Compound 4: the middle estimate sits 1.8-fold (0.25 log units) above what was measured; measured number inside the range.
By their numbers in this assay, from the lowest: compounds 4, 2 and 3 (each within the scatter of the next, the first and the last beyond it); then compound 1.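

The cleanest reading comes from the pair that keeps the 4-chlorophenyl ring and adds only the amino link on the carbonyl carbon (a 1.6-fold lower number from compound 2 to compound 4 (0.20 log units; within the scatter)), so in this assay that link alone is not shown to change growth inhibition, though it is clearly tolerated here. Within the data shown here, the steps from the other two compounds (a 2.1-fold lower number from compound 3 to compound 4 (0.33 log units; beyond the scatter) and a 5.4-fold lower number from compound 1 to compound 4 (0.74 log units; beyond the scatter)) both lie beyond the scatter, but each swaps the ring substituent as well as adding the link, and the second is the largest step at this position so far. No measured evidence explains these differences.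

On these data alone, it remains open whether (4-methoxyphenyl)amino or (2-bromophenyl)amino would track their directly linked counterparts in the same way. The compounds shown also leave untested an oxygen link, as in (4-chlorophenyl)oxy, or a longer chain between the carbonyl carbon and the ring.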